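Adding Fluorine to the Core: Metabolic Stability Outlook

The source may report more compounds than this note shows. Statements on the series, on what has been measured and on what is new or still open speak of the compounds shown alone.

Compound 1 `CC(c1ccc2ncc(-c3cnn(C)c3)cc2c1)n1nnc2ncc(-c3ccc(C(N)=O)c(F)c3)nc21`: 30 uL/min
Compound 2 `CC(c1ccc2ncc(-c3cnn(C)c3)cc2c1)n1nnc2ncc(-c3ccncc3)nc21`: 78 uL/min

In an ADME assay on microsomes from liver (Mus musculus) for metabolic stability, read by LC-MS, using NADPH, with stated times of 5 min and 30 min, tested at 1 uM (on this read-out lower numbers stand for slow clearance and higher numbers for fast clearance), compound 1 stands lowest of the two numbers. Among the compounds with values here, the only measured step is a 2.6-fold higher number from compound 1 to compound 2 (0.41 log units; beyond the scatter), a swap of one whole aryl group. Compound 3 `CC(c1cc2cc(-c3cnn(C)c3)cnc2cc1F)n1nnc2ncc(-c3ccc(C(N)=O)c(F)c3)nc21` differs from compound 1 by fluoro in place of hydrogen on an aromatic carbon. Within the data shown here, no measured step touches this part of the shared core, so nothing known speaks for a shift in either direction. In this assay compound 3 is therefore estimated at 30 uL/min, within a range of 15 uL/min to 60 uL/min. The step of no change at the digits printed from compound 1 to compound 3 (within the scatter) is expected to stay within the scatter.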

Compound 3, intrinsic clearance in a liver preparation (reported as CLH), per the amount of preparation that the assay uses: 6 uL/min
Compound 3: middle estimate off by 5.0-fold (0.70 log units), on the high side, and the stated range ends above it.
By their numbers in this assay, from the lowest: compound 3; then compound 1; then compound 2.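

Placing fluoro in place of hydrogen on an aromatic carbon of the shared core gives a 5.0-fold lower number from compound 1 to compound 3 (0.70 log units; beyond the scatter) in this assay. This position is therefore not neutral: a change of 1 heavy atom moves the read-out beyond the scatter, toward slow clearance. Nothing measured here gives a reason for the shift.

Going by these compounds, whether chloro, methoxy or an amine at this carbon would move the number the same way stays open. So does whether fluoro here would give a similar step alongside the pyridin-4-yl group of compound 2.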